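Adding an Amino Group: What Compound 4 May Tolerate

The source may hold more compounds than are shown below. What is called first, only, known or untested is meant among the compounds shown, and "the series" means these compounds.

Of the compounds shown here, three have been measured in a functional assay on MT2 cells (Homo sapiens) for cytotoxicity, read by MTT assay; a lower number here means that less compound is tolerated, a higher number that more compound is tolerated. Compound 1 `CC(C)=CCOc1cc(Nc2ncccn2)ccc1Cl` gives 2500 nM. Compound 2 `COc1ccnc(Nc2ccc(Cl)c(OCC=C(C)C)c2)n1` gives 9000 nM, and compound 3 `COc1ccnc(Nc2ccc(C)c(OCC=C(C)C)c2)n1` gives 41000 nM. Among these three numbers compound 2 holds the second highest place: the step of a 3.6-fold higher number from compound 1 to compound 2 (0.56 log units; beyond the scatter) separates it from compound 1 below, and the step of a 4.6-fold higher number from compound 2 to compound 3 (0.66 log units; beyond the scatter) separates it from compound 3 above.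

Compound 4 `COc1cc(N)nc(Nc2ccc(Cl)c(OCC=C(C)C)c2)n1` differs from compound 2 in one place: amino in place of hydrogen on an aromatic carbon. Among the compounds with values here, no measured step swaps a hydrogen for an amino group, so there is no direct precedent. The nearest guide is the step from compound 1 to compound 2, where a small group also entered the same six-membered aromatic ring with two nitrogens and the number rose modestly. The step from compound 2 to compound 3 changed a different ring and is a weaker guide. On this basis a modest rise, or no step beyond the scatter, is expected for compound 4 in this assay.

The estimate for compound 4 is 13000 nM, with a range of 5000 nM to 35000 nM. This estimate means an expected step of a 1.4-fold higher number from compound 2 to compound 4 (0.16 log units; within the scatter).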

Compound 4, half-maximal cytotoxic concentration: 19000 nM
Compound 4: the middle estimate sits 1.5-fold (0.16 log units) below what was measured, and the stated range covers the measured number.
By their numbers in this assay, from the lowest: compound 1; then compound 2; then compound 4; then compound 3.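

Putting amino in place of hydrogen, on an aromatic carbon next to the ring nitrogen, gives a 2.1-fold higher number from compound 2 to compound 4 (0.32 log units; beyond the scatter) in this assay, so this position accepts a new group without the number falling. The same ring had already shown one such change, methoxy in place of hydrogen, with a 3.6-fold higher number from compound 1 to compound 2 (0.56 log units; beyond the scatter), and among the compounds shown both hydrogen replacements on this ring now move the number upward, with none going against them. Nothing available here explains why the amino group has this effect on cytotoxicity, so the step stands as an observation only.

As far as these compounds go, whether a methylamino or dimethylamino group, or a hydroxyl group, at this same place would move the number in the same direction remains open. Also open, from the compounds shown here alone, is whether amino would give a similar step on the core of compound 3, which carries methyl in place of chloro and already has the highest number of the series.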